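A few compounds are considered here, and "the series" means these few. Any claim that something is new, unique, unknown or untested is made for them only; others in the source may bear on it.

Compound 2 `Cc1cc(NCc2cccs2)n2nc(C)c(-c3ccccc3)c2n1` carries a (thiophen-2-yl)methyl on a nitrogen on an aromatic ring of the shared core. In a physicochemical assay for solubility, read by HPLC, using the shake flask method, measured as kinetic solubility, with a stated time of 2 h, at pH 7.4 (a lower number here means a less soluble compound, a higher number a more soluble compound), compound 2 returns only a limit of the assay, < 5000 nM. Compound 1 `Cc1cc(Nc2ccccn2)n2nc(C)c(-c3ccccc3)c2n1` differs from it by pyridin-2-yl in that place. In this assay compound 1 likewise returns a limit, < 5000 nM. The step that the two limits leave unreadable from compound 1 to compound 2 has no readable size, since both sit at the limit of < 5000 nM in this assay, at which 2 of the 2 values shown sit. Compound 3 `Cc1cc(NCc2ncnn2C)n2nc(C)c(-c3ccccc3)c2n1` brings the change (1-methyl-1H-1,2,4-triazol-5-yl in place of thiophen-2-yl on a saturated chain carbon bound to a nitrogen on an aromatic ring). Among the measured compounds shown here, no measured step covers it, so an at least 2.0-fold higher number from compound 2 to compound 3 (0.30 log units; that floor lies within the scatter) is expected to stay modest. Compound 3 is estimated at 10000 nM, within 2500 nM to 40000 nM.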

Compound 3, solubility: 185000 nM
The estimate for compound 3 lay 19-fold (1.27 log units) below the measured number, and the stated range ends below it.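

Among the compounds shown here, on a saturated chain carbon bound to a nitrogen on an aromatic ring, 1-methyl-1H-1,2,4-triazol-5-yl in place of thiophen-2-yl gives the first readable number in this assay, with an at least 37-fold higher number from compound 2 to compound 3 (1.56 log units; beyond the scatter). Against the directly attached pyridin-2-yl, (1-methyl-1H-1,2,4-triazol-5-yl)methyl gives an at least 37-fold higher number from compound 1 to compound 3 (1.56 log units; beyond the scatter), so a change at this place can move the read-out beyond the scatter. Only compound 3 stands clear of the limit: the limit of < 5000 nM in this assay, at which 2 of the 3 values shown sit.

As far as these compounds go, both steps start from a limit, so their full size stays open. From the compounds shown here alone, whether a morpholine or a triazole without the methyl on that chain carbon gives a similar number also stays open.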